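This account rests on a few compounds, and the source may have more. Where it says the series, first, only, none or still open, it means among the compounds named here.

For the measured compounds named here, compound 2 `Cc1cccnc1-c1cnc(C(=O)CCCCCCc2ccccc2)o1` gives 15 nM in an assay (Rattus norvegicus) for inhibition of Fatty-acid amide hydrolase 1 (Homo sapiens) (on this read-out lower numbers stand for stronger inhibition and higher numbers for weaker inhibition), the lowest of the two numbers measured so far; its nearest neighbour is compound 1 `O=C(CCCCCCc1ccccc1)c1ncc(-c2cccc(O)c2)o1`, which gives 50 nM. Going by the values given here, the one measured step, a 3.3-fold lower number from compound 1 to compound 2 (0.52 log units; beyond the scatter), changed the aromatic group on the same carbon and was modest. Compound 3 `O=C(CCCCCCc1ccccc1)c1ncc(-c2ncccn2)o1` carries the change (pyrimidin-2-yl in place of 3-methylpyridin-2-yl on an aromatic carbon). Among the compounds with values here, no measured step covers this exact exchange, so only a small shift, if any beyond the scatter, is expected, with the step of a 2.0-fold higher number from compound 2 to compound 3 (0.30 log units; within the scatter). Compound 3 is therefore estimated at 30 nM, within 10 nM to 100 nM.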

Compound 3, inhibition constant: 5.3 nM
For compound 3 the middle estimate is 5.7-fold (0.75 log units) above the measured one, and the stated range ends above it.
By their numbers in this assay, from the lowest: compound 3; then compound 2; then compound 1.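

On the aromatic carbon next to the ring oxygen, the group still has room to lower the number in this assay: pyrimidin-2-yl gives a 2.8-fold lower number from compound 2 to compound 3 (0.45 log units; beyond the scatter) and a 9.4-fold lower number from compound 1 to compound 3 (0.97 log units; beyond the scatter). Among these three compounds, all separated by steps beyond the scatter, pyrimidin-2-yl therefore ranks first, ahead of both 3-methylpyridin-2-yl and 3-hydroxyphenyl, and the methyl-bearing ring proves unnecessary for a low number. No available evidence bears on this result. Open remains whether an unsubstituted pyridin-2-yl would match pyrimidin-2-yl, and whether an amine or a carboxylic acid on the pyrimidine ring would keep the gain.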